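This account rests on a few compounds, and the source may have more. Where it says the series, first, only, none or still open, it means among the compounds named here.

Measured compounds:
compound 1 `Cc1ccc(/C=C/C[C@H]2C[C@@H]([C@@H](O)c3ccccc3)CO[C@@H]2c2ccccc2)cc1C`, 9880 nM;
compound 2 `O[C@@H](c1ccccc1)[C@H]1CO[C@H](c2ccccc2)[C@@H](C/C=C/c2cccnc2)C1`, > 100000 nM;
compound 3 `O[C@@H](c1ccccc1)[C@H]1CO[C@H](c2ccccc2)[C@@H](C/C=C/c2ccc(F)cc2)C1`, 8110 nM.

In a functional assay on HL-60 cells (Homo sapiens) for cytotoxicity, read by WST assay, with a stated time of 48 h (a higher number here means a weaker inhibitor, a lower number a stronger inhibitor), compound 3 gives 8110 nM, the lowest of the two numbers, with compound 1 nearest at 9880 nM. For compound 2 the value > 100000 nM is a limit of the assay, not a number. Compound 4 `O[C@@H](c1ccccc1)[C@H]1CO[C@H](c2ccccc2)[C@@H](C/C=C/c2ccccc2F)C1` differs from compound 3 by 2-fluorophenyl in place of 4-fluorophenyl on a double-bonded chain carbon bound to a double-bonded chain carbon. For the measured compounds named here, no measured step moves a fluorine around the ring; the closest comparison, a 1.2-fold lower number from compound 1 to compound 3 (0.09 log units; within the scatter), lies within the scatter, while an at least 12-fold lower number from compound 2 to compound 3 (1.09 log units; beyond the scatter) concerns the pyridin-3-yl group. The expected step is therefore a 1.0-fold lower number from compound 3 to compound 4 (0.01 log units; within the scatter), none beyond the scatter. Compound 4 is estimated at 8000 nM, between 3500 nM and 20000 nM.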

Compound 4, half-maximal inhibitory concentration: 9530 nM
Compound 4: middle estimate off by 1.2-fold (0.08 log units), on the low side; the range from low to high includes it.
By their numbers in this assay, from the lowest: compounds 3, 4 and 1 (each within the scatter of the next). At a limit, above all of these: compound 2.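

In this assay the fluorine can now be compared in two places: 2-fluorophenyl in place of 4-fluorophenyl gives (a 1.2-fold higher number from compound 3 to compound 4 (0.07 log units; within the scatter)), so at this chain position the change leaves the number within the scatter. The 3,4-dimethylphenyl group cannot be told apart from 2-fluorophenyl either (a 1.0-fold lower number from compound 1 to compound 4 (0.02 log units; within the scatter)), whereas pyridin-3-yl stands apart (an at least 10-fold lower number from compound 2 to compound 4 (1.02 log units; beyond the scatter)). That last step rests on a limit for compound 2, not a number: the limit of > 100000 nM in this assay, at which 1 of the 4 values shown sits. Still open, going by these compounds, is whether 3-fluorophenyl, or a phenyl carrying an amine or a carboxylic acid, would stay in this range.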